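This account rests on a few compounds, and the source may have more. Where it says the series, first, only, none or still open, it means among the compounds named here.

Measured so far:
compound 1, `COc1cc(-c2cc(/C=C/C(=O)c3ccc(N)cc3)[nH]n2)cc(OC)c1OC`: 78%
compound 2, `COc1ccc(C(=O)/C=C/c2cc(-c3cc(OC)c(OC)c(OC)c3)n[nH]2)cc1OC`: 32%

The series is a set of chalcone-like compounds in which a pyrazole bearing a 3,4,5-trimethoxyphenyl group is linked through a double bond to a carbonyl carbon carrying a second aromatic ring. In a functional assay on DU-145 cells (Homo sapiens) for cytotoxicity, read by sulforhodamine B assay, with a stated time of 48 h, tested at 1 uM (a lower number here means a stronger effect, a higher number a weaker effect of the compound at the concentration tested), compound 1 gives 78%, while compound 2 gives 32%. Among the measured compounds shown here, the only measured step so far is a number 46 percentage points lower from compound 1 to compound 2 (beyond the scatter), so compound 2 has the lowest of the two numbers and thus the stronger effect seen to date.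

Compound 3, `COc1ccc(C(=O)/C=C/c2cc(-c3cc(OC)c(OC)c(OC)c3)n[nH]2)cc1`, differs from compound 2 only at that same ring on the carbonyl carbon: hydrogen in place of methoxy on an aromatic carbon. For the measured compounds named here, the one measured step bears on this change only loosely, since it swapped a different substituent pattern on that ring, yet it shows that this ring can move the read-out a great deal. Taking away a single methoxy is a smaller alteration, so a modest weakening is expected, estimated as a number 13 percentage points higher from compound 2 to compound 3 (beyond the scatter). Compound 3 is therefore expected to show about 45%, within a range from 25% to 70%.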

Compound 3, a percentage reported as activity, at one concentration (the size of the read-out at that concentration, not a potency): 76%
Estimate against measurement, compound 3: 31 percentage points below; the whole stated range lies below it.
By their numbers in this assay, from the lowest: compound 2; then compounds 3 and 1 (each within the scatter of the next).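

The methoxy that leaves compound 2 sits ortho to a methoxy group, and going from 3,4-dimethoxyphenyl to 4-methoxyphenyl in this assay gives a number 44 percentage points higher from compound 2 to compound 3 (beyond the scatter) and so takes away most of the effect seen with compound 2. This single group therefore matters a great deal at this site, whereas the earlier step could only show that changing the whole ring pattern mattered. Methoxy in place of amino on the same ring gives a number 2 percentage points lower from compound 1 to compound 3 (within the scatter) in this assay so, with only one methoxy or one amino group on that ring, these two compounds cannot be told apart, and nothing available explains why the second methoxy counts for so much.

Going by these compounds, it remains open whether the effect depends on methoxy itself or whether another group at that carbon, such as ethoxy, hydroxyl or fluorine, would give a similar reading. On these data alone, it is also open whether a third methoxy on this ring, giving a 3,4,5-trimethoxyphenyl group like the one on the other side of the core, would strengthen the effect further.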